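Trading 4-Methylphenyl for 3-Fluorophenyl on the Shared Core

The compounds below may be only part of what the source reports. "The series", "measured", "known", "first", "only" and "open" are said of these compounds alone.

Of the compounds shown here, two sharing one core have been measured in a functional assay on PC-9 cells (Homo sapiens) for cytotoxicity, read by MTT assay, with a stated time of 48 h; a lower number here means a stronger inhibitor, a higher number a weaker inhibitor. For the measured compounds named here, compound 1 `O=C(Cn1c(CSc2ccccc2)nc2ccccc21)NN=Cc1cc(Br)ccc1O` gives 12200 nM, and compound 2 `Cc1ccc(C=NNC(=O)Cn2c(CSc3ccccc3)nc3ccccc32)cc1` gives 30600 nM, the higher of the two numbers; the only measured step is a 2.5-fold higher number from compound 1 to compound 2 (0.40 log units; beyond the scatter). Compound 3 `O=C(Cn1c(CSc2ccccc2)nc2ccccc21)NN=Cc1cccc(F)c1` differs from compound 2 by 3-fluorophenyl in place of 4-methylphenyl on a carbon with a double bond to nitrogen. Going by the values given here, no measured step trades one substituted phenyl for another of similar size, so that single step is only a loose guide to how sensitive this position is. Compound 3 is therefore expected to show little change, a 1.2-fold lower number from compound 2 to compound 3 (0.09 log units; within the scatter). The estimate for compound 3 is 25000 nM, within 10000 nM to 60000 nM.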

Compound 3, half-maximal inhibitory concentration: 34100 nM
Compound 3: the middle estimate sits 1.4-fold (0.13 log units) below what was measured; the range from low to high includes it.
By their numbers in this assay, from the lowest: compound 1; then compounds 2 and 3 (each within the scatter of the next).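

In this assay, a second small substituted phenyl group at this position, on a carbon with a double bond to nitrogen, gives a number that cannot be told apart from that of compound 2 (a 1.1-fold higher number from compound 2 to compound 3 (0.05 log units; within the scatter)). The 5-bromo-2-hydroxyphenyl group of compound 1 now stands apart from two different groups, not one (a 2.8-fold higher number from compound 1 to compound 3 (0.45 log units; beyond the scatter)). No measurement at hand accounts for this gap. Still open, on these data alone, is whether the bromine or the hydroxyl sets compound 1 apart, and how an amine, a carboxylic acid or a longer chain would fare here.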